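The compounds below may be only part of what the source reports. "The series", "measured", "known", "first", "only" and "open" are said of these compounds alone.

Compound 1 `C#Cc1cn([C@@H]2O[C@H](CO)[C@@H](O)[C@H]2O)c2ncnc(N(C)C)c12` gives 110 nM in a functional assay on K562 cells (Homo sapiens), read by MTT assay, with a stated time of 72 h (a higher number here means a weaker inhibitor, a lower number a stronger inhibitor), the lowest of the two numbers shown. Compound 3 `C#Cc1cn([C@@H]2O[C@H](CO)[C@@H](O)[C@H]2O)c2ncnc(OC)c12` gives 300 nM in this assay, a step of a 2.7-fold higher number from compound 1 to compound 3 (0.44 log units; beyond the scatter). Compound 2 `C#Cc1cn([C@@H]2O[C@H](CO)[C@@H](O)[C@H]2O)c2ncnc(NC)c12` gives > 20000 nM in this assay, which is a limit of the assay rather than a number. Only compound 2 sits at the limit of > 20000 nM in this assay, at which 1 of the 3 values shown sits. The measured steps, an at least 180-fold higher number from compound 1 to compound 2 (2.25 log units; beyond the scatter) and an at least 66-fold lower number from compound 2 to compound 3 (1.82 log units; beyond the scatter), concern the dimethylamino, methylamino or methoxy group, not the carbon changed in compound 4 `CN(C)c1ncnc2c1c(-c1cccs1)cn2[C@@H]1O[C@H](CO)[C@@H](O)[C@H]1O`, which differs from compound 1 by thiophen-2-yl in place of ethynyl on an aromatic carbon. Going by the values given here, no measured step bears on this change, so a step of no more than modest size in this assay is expected, direction uncertain, a 1.8-fold higher number from compound 1 to compound 4 (0.26 log units; within the scatter). Compound 4 is estimated at 200 nM (40 nM to 1500 nM) in this assay.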

Compound 4, half-maximal inhibitory concentration: > 20000 nM
Compound 4: a limit, no number (the forecaster's own chance of this, stated with the estimate: 5%); middle value at least 100-fold (2.00 log units) from the limit.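

In this assay, going by these compounds alone, the earlier steps concerned only the dimethylamino, methylamino or methoxy group; this one shows that the carbon bearing ethynyl matters too, with thiophen-2-yl in place of ethynyl giving an at least 180-fold higher number from compound 1 to compound 4 (2.25 log units; beyond the scatter). A change at this carbon alone is enough to take compound 1 to the limit of the assay. Compound 4 gives > 20000 nM, a limit and not a number, and it stands there with one other compound: the limit of > 20000 nM in this assay, at which 2 of the 4 values shown sit.

Compound 4 brings a ring and more heavy atoms in a single change, and these two cannot be separated here. As far as these compounds go, whether a nitrile, a propynyl chain or a furan-2-yl ring on this carbon would stay near compound 1 remains open.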